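Cytotoxicity of two sulfonamide triazoles and a fluorophenyl analogue

This account rests on a few compounds, and the source may have more. Where it says the series, first, only, none or still open, it means among the compounds named here.

Measured compounds:
compound 1 `Cc1cccc(-n2cc(-c3ccccc3NS(=O)(=O)c3c[nH]c(=O)[nH]c3=O)nn2)c1`, 23700 nM
compound 2 `Cc1ccccc1-n1cc(-c2cccc(NS(=O)(=O)c3c[nH]c(=O)[nH]c3=O)c2)nn1`, 21500 nM

In an ADME assay on GES1 cells (Homo sapiens) for cytotoxicity, read by MTT assay, with a stated time of 24 h (on this read-out lower numbers stand for higher toxicity in this test and higher numbers for lower toxicity in this test), compound 2 gives 21500 nM. Among the measured compounds shown here, compound 1, the only other measured compound, gives 23700 nM in this assay, and the gap between the two numbers lies within the scatter, so the two compounds cannot be told apart on this read-out.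

Compound 3 `O=c1[nH]cc(S(=O)(=O)Nc2cccc(-c3cn(-c4cccc(F)c4)nn3)c2)c(=O)[nH]1` has not yet been measured. It differs from compound 2 in one place: 3-fluorophenyl in place of 2-methylphenyl on an aromatic nitrogen. For the measured compounds named here, no step between two measured compounds is available to gauge such a change. With both measured numbers so close together, the account expects no step beyond the scatter from compound 2 to compound 3, that is a 1.0-fold higher number from compound 2 to compound 3 (0.01 log units; within the scatter). Compound 3 is therefore estimated at 22000 nM in this assay, with a range from 10000 nM to 45000 nM.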

Compound 3, half-maximal cytotoxic concentration: "not toxic" (no number reported)
Compound 3: no number reported; there is nothing to compare the estimate with.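

Among the compounds shown here, compound 3 is reported as not toxic without a number, and no step from compound 2 to compound 3 can be read. The compounds shown leave open how 3-fluorophenyl in place of 2-methylphenyl changes the half-maximal cytotoxic concentration. No supporting measurement bears on this result.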